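Extending the carboxy chain of compound 1

The compounds below may be only part of what the source reports. "The series", "measured", "known", "first", "only" and "open" are said of these compounds alone.

In a functional assay on the whole organism for inhibition, with Rattus norvegicus as the target (a higher number here means that more compound is needed for the effect, a lower number that less compound is needed), compound 1 `O=C(O)CN1C(=O)[C@@H](NC(=O)[C@@H](CS)Cc2ccccc2)CCc2ccccc21` gives 0.52 umol/kg, and compound 2 `O=C(O)CN1C(=O)[C@@H](NC(=O)[C@@H](S)Cc2ccccc2)COc2ccccc21` gives 0.26 umol/kg. These two values lie within the scatter of each other. Compound 3 `O=C(O)CN1C(=O)[C@@H](NC(=O)[C@@H](CS)Cc2ccccc2)COc2ccccc21` gives 5.8 umol/kg, beyond the scatter of both and the highest number of the three.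

Compound 4 `O=C(O)CCN1C(=O)[C@@H](NC(=O)[C@@H](CS)Cc2ccccc2)CCc2ccccc21` keeps the core of compound 1 and differs as follows: carboxymethyl in place of carboxy on a saturated chain carbon bound to an amide-type nitrogen in a ring. Read one bond further out, this is carboxymethyl to 2-carboxyethyl.

For the measured compounds named here, no measured step touches this place. Going by the values given here, the only step available, sulfanylmethyl in place of sulfanyl at another place, gave a 22-fold higher number from compound 2 to compound 3 (1.35 log units; beyond the scatter). It is large, but it offers only a loose guide to direction and a generous upper bound on size. A moderate step is therefore expected, smaller than that one and towards a higher number: a 2.9-fold higher number from compound 1 to compound 4 (0.46 log units; beyond the scatter).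

Compound 4 is estimated at 1.5 umol/kg, with an expected range of 0.4 umol/kg to 6 umol/kg.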

Compound 4, dose for half-maximal effect: 13.3 umol/kg
Compound 4: the middle estimate sits 8.9-fold (0.95 log units) below what was measured, and the stated range ends below it.
By their numbers in this assay, from the lowest: compounds 2 and 1 (each within the scatter of the next); then compound 3; then compound 4.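

The carboxy chain is a sensitive place in this assay: with the sulfanylmethyl group and the core of compound 1 held fixed, carboxymethyl to 2-carboxyethyl gives a 26-fold higher number from compound 1 to compound 4 (1.41 log units; beyond the scatter). For the compounds shown here, until now, the only large step was at the other end of the molecule, a 22-fold higher number from compound 2 to compound 3 (1.35 log units; beyond the scatter), so a large change is now seen at both places, and in both steps the group is lengthened and the number rises. Nothing available bears on why this chain length matters so much.

Going by these compounds, it remains open whether a still longer chain, such as 3-carboxypropyl, continues this rise or whether an ester or an amide in place of the carboxylic acid is tolerated at this place. On these data alone, the effect of 2-carboxyethyl on the core of compound 3 also remains open.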